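Para-substituent swap on the benzylsulfanyl arm of the shared core

The compounds below may be only part of what the source reports. "The series", "measured", "known", "first", "only" and "open" are said of these compounds alone.

Two members of the series have been measured in a functional assay on the whole organism (artery, strain albino) with Rattus norvegicus as the target, with a stated time of 30 min, at a dose of 10 mg/kg by the oral route; a lower number here means less inhibition, a higher number more inhibition at the dose given (going by the name of the read-out). Compound 1 `CC1=C(C(=O)Nc2ccc(F)cc2)C(c2ccc([N+](=O)[O-])cc2)N=C(SCc2cccc(Cl)c2)N1` gives 4.1% in this assay, and compound 2 `CC1=C(C(=O)Nc2ccc(F)cc2)C(c2ccc([N+](=O)[O-])cc2)N=C(SCc2ccc(Cl)cc2)N1` gives 6.7% in this assay. Going by the values given here, compound 2 stands with compound 1 in a single cluster: the only step recorded, a number 2.6 percentage points higher from compound 1 to compound 2 (within the scatter), is within the scatter, so the two numbers count as level, and both are small percentages of inhibition in this assay at this dose.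

Compound 3 `CC1=C(C(=O)Nc2ccc(F)cc2)C(c2ccc([N+](=O)[O-])cc2)N=C(SCc2ccc(F)cc2)N1` is the next member, unmeasured so far. It differs from compound 2 by fluoro in place of chloro on an aromatic carbon on the same benzyl ring that carried the earlier change. Among the compounds with values here, no measured step bears directly on a fluoro in place of chloro; the one step that touches this ring, a number 2.6 percentage points higher from compound 1 to compound 2 (within the scatter), is small. In this assay the expected step is therefore a number 0.7 percentage points lower from compound 2 to compound 3 (within the scatter), nothing beyond the scatter. Compound 3 is expected to give 6% in this assay, with a range from 0% to 18%.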

Compound 3, a percentage reported as inhibition, in the whole organism at one dose (the size of the read-out at that dose, not a potency): 5.7%
For compound 3 the middle estimate is 0.3 percentage points above the measured one, within the range that was stated.
By their numbers in this assay, from the lowest: compounds 1, 3 and 2 (each within the scatter of the next).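

Working notes on the benzyl ring: in this assay, the change of the halogen itself, fluoro in place of chloro on an aromatic carbon para to a large group, gives a number 1 percentage points lower from compound 2 to compound 3 (within the scatter), so at this position the two halogens read as level. The comparison of 4-fluorophenyl in place of 3-chlorophenyl, which alters both the halogen and its place on the ring, gives a number 1.6 percentage points higher from compound 1 to compound 3 (within the scatter), so neither of the two changes tried on this ring separates the compounds, and compound 1, compound 2 and compound 3 stay together as one cluster of small percentages at this dose. No measurement at hand accounts for this flat picture, and no explanation can be offered for it.

Open, as far as these compounds go, is whether anything on this arm moves the number beyond the scatter, for example an amine or a carboxylic acid on the ring in place of the halogen, or a longer chain between the sulfur and the ring. The nitro group and the fluorinated anilide stay the same in all three compounds, so what these parts of the shared core contribute to the read-out cannot be told from these numbers.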